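The source may report more compounds than this note shows. Statements on the series, on what has been measured and on what is new or still open speak of the compounds shown alone.

Working notes on the sulfonamide series at a functional assay for agonist activity at growth hormone secretagogue receptor type 1 (Homo sapiens), read by FLIPR; a lower number here means a smaller maximal response, a higher number a larger maximal response.

Three compounds carry a measurement. Compound 1 `C[C@@H]1CN(c2cc(NS(=O)(=O)c3ccc(-c4ccccn4)s3)ccc2C#N)C[C@H](C)N1` gives 0.9. Compound 2 `COc1ccc(N2C[C@@H](C)N[C@@H](C)C2)cc1NS(=O)(=O)c1ccc(-c2ccccc2)cc1` gives 1. Compound 3 `COc1ccc(N2C[C@@H](C)N[C@@H](C)C2)cc1NS(=O)(=O)c1cccc(-c2ccco2)c1` gives 1. Compound 2 stands level with compound 3 at the digits shown, and compound 1 lies within the usual scatter of both, so the three measured values cannot be told apart; each reaches a response close to that of the reference agonist.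

The next compound, compound 4 `COc1ccc(N2C[C@@H](C)N[C@@H](C)C2)cc1NS(=O)(=O)c1ccc(OCc2ccccc2)cc1`, is not yet measured. It differs from compound 2 by one change, (benzyloxy in place of phenyl on an aromatic carbon). For the measured compounds named here, no pair of measured compounds shows this change or anything like it, so there is no measured step to lean on. All three measured compounds, with different groups in this region of the sulfonamide, give near-full responses, which argues against a large shift in either direction; a small fall cannot be excluded.

Compound 4 is therefore expected to give about 0.9, with a range from 0.65 to 1. The expected step a number 0.10 lower from compound 2 to compound 4 (within the scatter) would be within or just beyond the scatter.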

Compound 4, intrinsic activity: the largest response reached, as a fraction of the reference agonist's: 0.8
For compound 4 the middle estimate is 0.10 above the measured one, and the stated range covers the measured number.
By their numbers in this assay, from the lowest: compounds 4, 1, 2 and 3 (each within the scatter of the next, the first and the last beyond it).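

In this assay, for the compounds shown here, benzyloxy in place of phenyl on an aromatic carbon, para to a large group, gives a number 0.20 lower from compound 2 to compound 4 (beyond the scatter) as the only step that can be read. This shows that the maximal response depends on the group at this position, a dependence the three earlier values could not reveal, although compound 4 at 0.8 still keeps most of the reference agonist's response. No supporting measurement bears on why the response falls with this change.

Going by these compounds alone, the single step does not separate the effect of the oxygen in benzyloxy from that of its additional carbon, and a phenoxy or phenethyl group at this position would be needed to tell them apart. From the compounds shown here alone, whether an amine or a carboxylic acid here would lower the response further remains open.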